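The compounds below may be only part of what the source reports. "The series", "measured", "known", "first", "only" and "open" are said of these compounds alone.

Measured so far: compound 1 `CC(C)COc1ncc(-c2cc(F)c(-c3nnc(S(=O)(=O)CC4CC4)[nH]3)cc2F)cc1Cl`, compound 2 `O=S(=O)(CC1CC1)c1nnc(-c2cc(F)c(-c3cnc(Oc4ccc(F)cc4F)c(Cl)c3)cc2F)[nH]1`, compound 3 `O=S(=O)(CC1CC1)c1nnc(-c2cc(F)c(-c3cnc(Oc4ccccc4C(F)(F)F)c(Cl)c3)cc2F)[nH]1`.

In an ADME assay on microsomes from liver (Homo sapiens) for metabolic stability (on this read-out higher numbers stand for fast clearance and lower numbers for slow clearance), compound 1 gives 67 uL/min. Compound 2 gives < 14 uL/min, which is a limit of the assay rather than a number. Compound 3 likewise gives < 14 uL/min, again only a limit, so compound 3 stands at the lowest reading the assay reports, as the limit of < 14 uL/min in this assay, at which 2 of the 3 values shown sit, shows. Compound 4 `O=S(=O)(CC1CC1)c1nnc(-c2cc(F)c(-c3cnc(Oc4ccc(F)cc4Cl)c(Cl)c3)cc2F)[nH]1` differs from compound 3 in one place: 2-chloro-4-fluorophenyl in place of 2-(trifluoromethyl)phenyl on an oxygen on an aromatic ring. Among the compounds with values here, the steps that bear on this are an at least 4.7-fold lower number from compound 1 to compound 2 (0.67 log units; beyond the scatter) and an at least 4.7-fold lower number from compound 1 to compound 3 (0.67 log units; beyond the scatter); both put a six-membered aromatic ring of carbon only on that oxygen in place of isobutyl, and both reached the limit. The step between them, a step that the two limits leave unreadable from compound 2 to compound 3, cannot be read. Compound 4 keeps such a ring there, so compound 4 is expected to stay at the limit, with a step that the limit leaves unreadable from compound 3 to compound 4 expected to be no step beyond the scatter. The estimate for compound 4 is 10 uL/min, from 5 uL/min to 20 uL/min.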

Compound 4, intrinsic clearance in a liver preparation (reported as CLH), per the amount of preparation that the assay uses: < 14 uL/min
Compound 4 ended at the assay's limit; the forecaster's own chance of this, stated with the estimate: 70%; the middle value lies beyond the limit too.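

With 2-chloro-4-fluorophenyl, a third substituted aromatic ring on this oxygen gives the same outcome as the first two: in this assay there is an at least 4.7-fold lower number from compound 1 to compound 4 (0.67 log units; beyond the scatter). The result therefore holds with chloro in place of fluoro and without trifluoromethyl on the ring. The steps among compound 2, compound 3 and compound 4 cannot be read, and all three sit at one limit: the limit of < 14 uL/min in this assay, at which 3 of the 4 values shown sit.

Any real order among these three rings remains open. So does how a ring carrying an amine or a carboxylic acid would read on this oxygen.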